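Pyridin-4-yl Replaced by 1,1-Dioxothian-4-yl: Expected Potency

This account rests on a few compounds, and the source may have more. Where it says the series, first, only, none or still open, it means among the compounds named here.

Of the compounds shown here, three sharing one core have been measured in a functional assay on cells for antagonist activity at C-X-C chemokine receptor type 4 (Homo sapiens), read by fluorescence and calcium flux, with stated times of 25 min and 90 s; a higher number here means a weaker inhibitor, a lower number a stronger inhibitor. Compound 2 `c1ccc2c(c1)CN[C@@H](CN(CCCCNCc1ccncc1)[C@H]1CCCc3cccnc31)C2` gives 22.7 nM, the lowest of the three numbers. Its nearest neighbour, compound 3 `c1ccc2c(c1)CN[C@@H](CN(CCCCNCC1CCCCC1)[C@H]1CCCc3cccnc31)C2`, gives 158 nM, and compound 1 `c1ccc(CN(CCCCN(C[C@H]2Cc3ccccc3CN2)[C@H]2CCCc3cccnc32)Cc2ccccn2)nc1`, the furthest, gives 664 nM. Compound 4 `O=S1(=O)CCC(CNCCCCN(C[C@H]2Cc3ccccc3CN2)[C@H]2CCCc3cccnc32)CC1` has not yet been measured in this assay. It differs from compound 2 in one place: 1,1-dioxothian-4-yl in place of pyridin-4-yl on a saturated chain carbon bound to an amine nitrogen. For the measured compounds named here, the one measured step that bears on this change is a 7.0-fold higher number from compound 2 to compound 3 (0.84 log units; beyond the scatter), where an aromatic six-membered ring gave way to a saturated six-membered ring at the same place. Compound 4 likewise carries a saturated six-membered ring there, though one that keeps two hydrogen-bond acceptors. A weakening of similar or somewhat smaller size than that step is therefore expected, giving an estimated 3.1-fold higher number from compound 2 to compound 4 (0.49 log units; beyond the scatter). Compound 4 is expected to give about 70 nM in this assay, within a range of 25 nM to 250 nM.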

Compound 4, half-maximal inhibitory concentration: 17 nM
For compound 4 the middle estimate is 4.1-fold (0.61 log units) above the measured one, and the stated range ends above it.
By their numbers in this assay, from the lowest: compounds 4 and 2 (each within the scatter of the next); then compound 3; then compound 1.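

In this assay the step is a 1.3-fold lower number from compound 2 to compound 4 (0.13 log units; within the scatter), so at this place, on a saturated chain carbon bound to an amine nitrogen, a non-aromatic six-membered ring can match pyridin-4-yl, which the cyclohexyl of compound 3 did not do. The step of a 9.3-fold lower number from compound 3 to compound 4 (0.97 log units; beyond the scatter) shows that the two non-aromatic rings are not interchangeable here, and so a 7.0-fold higher number from compound 2 to compound 3 (0.84 log units; beyond the scatter) cannot be read as the price of losing an aromatic ring as such. Nothing measured here accounts for the difference between the 1,1-dioxothian-4-yl and cyclohexyl rings.

Going by these compounds, whether a tetrahydropyran-4-yl ring, with a single ring oxygen, or a piperidin-4-yl ring, with a ring amine, would read like compound 4 or like compound 3 remains open. So does the effect of a longer chain carrying the 1,1-dioxothian-4-yl ring.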